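Swapping an Amide for an Aminopyridine: Expected Cytotoxicity

This account rests on a few compounds, and the source may have more. Where it says the series, first, only, none or still open, it means among the compounds named here.

Measured so far:
compound 1 `CC(=O)N1CCC(C(=O)N(CCCN2CCC(CNC(=O)c3cnccn3)CC2)c2ccc(C)c(Cl)c2)CC1`: > 52400 nM
compound 2 `CC(=O)N1CCC(C(=O)N(CCCN2CCN(Cc3ccc(C(F)(F)F)cc3)CC2)c2ccc(C)c(Cl)c2)CC1`: 30500 nM

In an ADME assay (Homo sapiens) for cytotoxicity (a higher number here means that more compound is tolerated, a lower number that less compound is tolerated), compound 1 shows only a limit of the assay, > 52400 nM, so no exact number is known for it; this is the limit of > 52400 nM in this assay, at which 1 of the 2 values shown sits. Compound 2 gives 30500 nM in this assay.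

Compound 3 `CC(=O)N1CCC(C(=O)N(CCCN2CCC(CNc3cc(C)ccn3)CC2)c2ccc(C)c(Cl)c2)CC1` differs from compound 1 in one place: 4-methylpyridin-2-yl in place of (pyrazin-2-yl)carbonyl on an amine nitrogen. Among the measured compounds shown here, no measured pair isolates this change, so its effect is unknown. Compound 3 is expected to sit close to compound 1, with the step of an at least 1.3-fold lower number from compound 1 to compound 3 (0.11 log units; that floor lies within the scatter) estimated to stay within the usual scatter. Compound 3 is estimated at 40000 nM, likely between 15000 nM and 100000 nM.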

Compound 3, half-maximal cytotoxic concentration: 17900 nM
Compound 3: the middle estimate sits 2.2-fold (0.35 log units) above what was measured, and the stated range covers the measured number.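

In this assay, putting 4-methylpyridin-2-yl in place of (pyrazin-2-yl)carbonyl on this amine nitrogen gives an at least 2.9-fold lower number from compound 1 to compound 3 (0.46 log units; beyond the scatter), so this position does respond to the change, and less compound is tolerated. That step is only a floor, because the value for compound 1 is a limit of the assay: the limit of > 52400 nM in this assay, at which 1 of the 3 values shown sits.

Which part of the change matters stays open. A pyridin-2-yl group without the methyl, or a pyridine-2-carbonyl group that keeps the carbonyl, would help separate the effect of the ring from that of the link.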